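The source may hold more compounds than are shown below. What is called first, only, known or untested is meant among the compounds shown, and "the series" means these compounds.

The measured compounds:
compound 1 `Nc1sc(-c2ccc(Cl)cc2)c(-c2ccc(Cl)cc2)c1C(=O)N1CCCC1`, 890 nM in a functional assay on A549 cells (Homo sapiens) for inhibition, read by sulforhodamine B assay, with a stated time of 72 h; a lower number here means a stronger inhibitor, a higher number a weaker inhibitor;
compound 2 `CC(C)(C)NC(=O)c1c(N)sc(-c2ccc(Cl)cc2)c1-c1ccc(Cl)cc1`, 8850 nM;
compound 3 `Nc1sc(-c2ccc(Cl)cc2)c(-c2ccc(Cl)cc2)c1C(=O)NCc1ccccc1`, 16300 nM.

Compound 3 gives the highest number of the three: compound 2 is nearest, within the scatter, while compound 1 is furthest, with an 18-fold higher number from compound 1 to compound 3 (1.26 log units; beyond the scatter). Compound 4 `CN1CCN(C(=O)c2c(N)sc(-c3ccc(Cl)cc3)c2-c2ccc(Cl)cc2)CC1` differs from compound 3 in one place: 4-methylpiperazin-1-yl in place of benzylamino on a carbonyl carbon. The step that bears on this is an 18-fold higher number from compound 1 to compound 3 (1.26 log units; beyond the scatter), which exchanged pyrrolidin-1-yl for benzylamino on the carbonyl carbon; the present change runs the other way, from benzylamino back to a ring on that carbon. Compound 4 is therefore expected to give a lower number than compound 3, a 6.5-fold lower number from compound 3 to compound 4 (0.81 log units; beyond the scatter), though 4-methylpiperazin-1-yl is not pyrrolidin-1-yl and a full return is not assured. Compound 4 is estimated at 2500 nM, within 600 nM to 10000 nM.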

Compound 4, half-maximal inhibitory concentration: 590 nM
Compound 4: middle estimate off by 4.2-fold (0.63 log units), on the high side, outside the stated range (below it).
By their numbers in this assay, from the lowest: compounds 4 and 1 (each within the scatter of the next); then compounds 2 and 3 (each within the scatter of the next).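

In this assay, 4-methylpiperazin-1-yl on the carbonyl carbon gives a 28-fold lower number from compound 3 to compound 4 (1.44 log units; beyond the scatter) against benzylamino and a 15-fold lower number from compound 2 to compound 4 (1.18 log units; beyond the scatter) against (tert-butyl)amino. Against pyrrolidin-1-yl it gives a 1.5-fold lower number from compound 1 to compound 4 (0.18 log units; within the scatter), so these two ring groups cannot be told apart here. Among these four compounds, the two without the amide hydrogen thus stand apart from the two that keep it.

Nothing given here explains this split. As far as these compounds go, whether it follows the ring or the missing amide hydrogen stays open, as does what morpholin-4-yl or methyl(benzyl)amino would give on that carbon.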